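The source may report more compounds than this note shows. Statements on the series, on what has been measured and on what is new or still open speak of the compounds shown alone.

Compound 2 `C[C@H]1CN(c2ncc(C(=O)Nc3ccc(F)c(F)c3)cc2Cl)CCN1C1CCN(Cc2ccc(Cl)cc2)CC1` was tested in a functional assay for antagonist activity at C-X-C chemokine receptor type 3 (Homo sapiens) (a lower number here means a stronger inhibitor, a higher number a weaker inhibitor), and gives 22 nM. Among the two numbers shown it stands at the lower end, but its only neighbour, compound 1 `C[C@H]1CN(c2ncc(C(N)=O)cc2Cl)CCN1C1CCN(Cc2ccc(Cl)cc2)CC1`, is close: in this assay compound 1 gives 39 nM, and the step of a 1.8-fold lower number from compound 1 to compound 2 (0.25 log units; within the scatter) stays within the scatter. Compound 3 `C[C@H]1CN(c2ncc(C(=O)N3CCCCC3)cc2Cl)CCN1C1CCN(Cc2ccc(Cl)cc2)CC1` differs from compound 2 in one place: piperidin-1-yl in place of (3,4-difluorophenyl)amino on a carbonyl carbon. For the measured compounds named here, the one measured step that speaks to this position, a 1.8-fold lower number from compound 1 to compound 2 (0.25 log units; within the scatter), changed the same amide and moved the number only a little, which suggests that this part of the molecule tolerates change without a large effect. On that basis the change is expected to give a step of a 1.8-fold higher number from compound 2 to compound 3 (0.26 log units; within the scatter) in this assay, with no clear direction beyond the scatter. Compound 3 is therefore estimated at 40 nM, with a likely range from 15 nM to 120 nM.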

Compound 3, half-maximal inhibitory concentration: 900 nM
The estimate for compound 3 lay 23-fold (1.35 log units) below the measured number; the measured number lies above the stated range.
By their numbers in this assay, from the lowest: compounds 2 and 1 (each within the scatter of the next); then compound 3.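

The result shows that this carbonyl position is not free to change: in this assay, the number rises sharply with a 41-fold higher number from compound 2 to compound 3 (1.61 log units; beyond the scatter) and just as clearly with a 23-fold higher number from compound 1 to compound 3 (1.36 log units; beyond the scatter). Amino and (3,4-difluorophenyl)amino, two very different groups, gave values within the scatter of each other, so the tolerance seen earlier does not extend to piperidin-1-yl, the only one of the three that leaves no hydrogen on the amide nitrogen. Nothing available here explains this loss.

The compounds shown cannot separate the missing amide hydrogen from the piperidine ring itself. A cyclohexylamino group would keep that hydrogen with a non-aromatic ring, whereas a dimethylamino group would remove it without any ring, so these two would help tell the possibilities apart.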